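Sulfone series: cyano to methoxy on the aryl sulfone

A few compounds are considered here, and "the series" means these few. Any claim that something is new, unique, unknown or untested is made for them only; others in the source may bear on it.

Measured compounds:
compound 1 `CC1CCN(c2c(S(=O)(=O)c3cccc(C#N)c3)cnc3cc(Cl)ccc23)CC1`: 94%
compound 2 `COc1cccc(S(=O)(=O)c2cnc3ccc(OC)cc3c2N2CCC(C)CC2)c1`: 0%
compound 3 `CC1CCN(c2c(S(=O)(=O)c3cccc(C#N)c3)cnc3cc(F)ccc23)CC1`: 92%

In an assay on isolated protein for displacement of a labelled ligand from metabotropic glutamate receptor 5 (Homo sapiens), with a stated time of 60 min, tested at 1 uM (on this read-out higher numbers stand for more inhibition at the one concentration tested (going by the name of the read-out) and lower numbers for less inhibition), compound 1 gives 94% and stands highest of the three numbers, though its gap to compound 3 is within the scatter: a number 2 percentage points lower from compound 1 to compound 3 (within the scatter). Compound 2 is far apart from the other two, giving 0%.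

Compound 4 `COc1cccc(S(=O)(=O)c2cnc3cc(Cl)ccc3c2N2CCC(C)CC2)c1` is unmeasured. It differs from compound 1 in one place: methoxy in place of cyano on an aromatic carbon. Read one bond further out, this is 3-cyanophenyl to 3-methoxyphenyl. Among the compounds with values here, no measured step bears directly on this change. Within the data shown here, the only measured step, halogen exchange on the core, is within the scatter and is of no help here. Compound 2 carries the methoxyphenyl sulfone but also differs from compound 4 on the core, so its low number is only a loose hint that the methoxyphenyl may read weaker. The step is therefore expected to be a drop of uncertain size, a number 44 percentage points lower from compound 1 to compound 4 (beyond the scatter), and compound 4 is estimated at 50%, within 5% to 90%.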

Compound 4, a percentage reported as inhibition, at one concentration (the size of the read-out at that concentration, not a potency): 93%
Compound 4: the middle estimate sits 43 percentage points below what was measured; measured number above the stated range.
By their numbers in this assay, from the lowest: compound 2; then compounds 3, 4 and 1 (each within the scatter of the next).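

Cyano and methoxy at this aromatic carbon, meta to a large group, are not told apart in this assay, with a number 1 percentage points lower from compound 1 to compound 4 (within the scatter), so with the chloro core of compound 1 the nitrile is not needed for a high reading at the one concentration tested. The low reading of compound 2 therefore gives no guide to compound 4, and it cannot be laid on the 3-methoxyphenyl alone. No measurement at hand explains why these two groups read alike.

With readings this high at one concentration, any difference in potency between the two groups remains unresolved. Also open, going by these compounds, are how an amine or a carboxylic acid would read at this place, and whether methoxy holds up on the fluoro core of compound 3.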